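A few compounds are considered here, and "the series" means these few. Any claim that something is new, unique, unknown or untested is made for them only; others in the source may bear on it.

Measured so far:
compound 1, `c1ccc2c(c1)CC2CCCN1CCN(c2cccc3c2OCCO3)CC1`, 0.16 mg/kg
compound 2, `c1ccc2c(c1)CC(CCN1CCN(c3cccc4c3OCCO4)CC1)C2`, 0.16 mg/kg

In a functional assay on the whole organism for antagonist activity, with Rattus norvegicus as the target (a lower number here means that less compound is needed, a higher number that more compound is needed for the effect), compound 1 gives 0.16 mg/kg, and in this assay compound 2 gives 0.16 mg/kg. Compound 2 stands level with compound 1 at the digits shown; the step of no change at the digits printed from compound 1 to compound 2 (within the scatter) lies within the scatter. Compound 3, `c1ccc2c(c1)CCC2CCN1CCN(c2cccc3c2OCCO3)CC1`, has not yet been measured in this assay. It differs from compound 2 in this way: 2,3-dihydro-1H-inden-1-yl in place of 2,3-dihydro-1H-inden-2-yl on a saturated chain carbon, two bonds along the chain from an amine nitrogen in a ring. Among the measured compounds shown here, the one measured step, no change at the digits printed from compound 1 to compound 2 (within the scatter), exchanged one ring-bearing group for another on the same chain carbon and left the dose unchanged, so it bears only loosely on a change that keeps the same group and moves its point of attachment. With nothing pointing either way, compound 3 is expected to show a step of no change at the digits printed from compound 2 to compound 3 (within the scatter), no change beyond the scatter. Compound 3 is therefore estimated at 0.16 mg/kg, with a range from 0.06 mg/kg to 0.45 mg/kg.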

Compound 3, minimum effective dose: 0.63 mg/kg
Estimate against measurement, compound 3: 3.9-fold (0.60 log units) below, and the stated range ends below it.
By their numbers in this assay, from the lowest: compounds 1 and 2 (each within the scatter of the next); then compound 3.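

In this assay, 2,3-dihydro-1H-inden-1-yl in place of 2,3-dihydro-1H-inden-2-yl on the same saturated chain carbon gives a 3.9-fold higher number from compound 2 to compound 3 (0.60 log units; beyond the scatter), so this position responds to how the group is attached, even with the same atoms on both sides of the change. Among the compounds shown here, the earlier compounds did not show this sensitivity, since the only step among them lay within the scatter, and the new compound also stands apart from the other measured neighbour, with a 3.9-fold higher number from compound 1 to compound 3 (0.60 log units; beyond the scatter). Nothing available explains why the point of attachment matters here.

The compounds shown leave open whether a longer chain on the 2,3-dihydro-1H-inden-1-yl group would bring the dose back level with compound 2. They also leave open how a hydroxyl or an amine on the five-membered ring would act at this position.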